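The source may report more compounds than this note shows. Statements on the series, on what has been measured and on what is new or still open speak of the compounds shown alone.

Three closely related compounds from this study have all been tested for their ability to kill a human colon cancer cell line. Compound 1 `COc1ccc(-c2cc3c(OC)cc(OC)cc3n(C)c2=O)cc1` carries a methyl on the aromatic nitrogen of the shared core; in a functional assay on HCT-15 cells (Homo sapiens) for cytotoxicity, read by colorimetric assay and MTT assay (on this read-out lower numbers stand for stronger inhibition and higher numbers for weaker inhibition), compound 1 gives 10000 nM. Compound 2 `COc1ccc(-c2cc3c(OC)cc(OC)cc3n(CCC#N)c2=O)cc1` differs only on that same chain, and in this assay compound 2 gives 10000 nM. Compound 3 `CCN(CC)C(=O)CCn1c(=O)c(-c2ccc(OC)cc2)cc2c(OC)cc(OC)cc21` carries a diethylcarbamoyl where compound 2 carries a cyano; in this assay compound 3 gives 10000 nM. Compound 1 therefore stands level with compounds 2 and 3 at the digits shown: the step of no change at the digits printed from compound 1 to compound 2 (within the scatter) and the step of no change at the digits printed from compound 1 to compound 3 (within the scatter) both lie within the scatter, as does the step of no change at the digits printed from compound 2 to compound 3 (within the scatter).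

Compound 4 `COc1cc(OC)c2cc(-c3ccc(OC(C)=O)cc3)c(=O)n(C)c2c1` has not yet been tested. It differs from compound 1 at a different place: acetyl in place of methyl on an oxygen on an aromatic ring. Among the compounds with values here, none of the measured steps touch that oxygen, so there is no direct guide; what is seen is that changing the substituent on the aromatic nitrogen left the read-out unchanged. On that basis the expected step of no change at the digits printed from compound 1 to compound 4 (within the scatter) is one of no change beyond the scatter. The value estimated for compound 4 in this assay is 10000 nM, within a range from 5000 nM to 20000 nM.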

Compound 4, half-maximal inhibitory concentration: 10000 nM
The estimate for compound 4 equals the measured number at the digits printed; the measured number falls inside the stated range.
By their numbers in this assay, from the lowest: compounds 1, 2, 3 and 4 (each within the scatter of the next).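

In this assay, replacing methoxy with acetoxy gives no change at the digits printed from compound 1 to compound 4 (within the scatter), so a change on an oxygen on an aromatic ring joins the changes on the aromatic nitrogen in leaving the read-out where it was. This is a different kind of change from those on the nitrogen chain: acetyl is larger than methyl and brings a carbonyl and a hydrogen-bond acceptor that methyl lacks, yet compound 4 stays level with compound 1. Nothing available here offers an explanation for this result.

All four compounds share one value, so none of them serves as a more active reference against which the importance of this oxygen could be judged. Going by these compounds, it remains open whether a free hydroxyl, an amine or a longer ester such as butanoyloxy at this place on the ring would move the number in this assay, or whether any such group would matter only on a compound with a lower value.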